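The compounds below may be only part of what the source reports. "The series", "measured", "known", "first", "only" and "open" are said of these compounds alone.

Measured so far in a functional assay on the whole organism (strain Holtzman) with Rattus norvegicus as the target; on this read-out higher numbers stand for an effect only at larger amounts of compound and lower numbers for an effect already at smaller amounts:
compound 1 `CCc1nn(C)c2c1C(c1cccc(F)c1)=NCC(=O)N2` gives 20 mg/kg
compound 2 `CCc1nn(C)c2c1C(c1cccc(F)c1)=NCC(=O)N2C` gives 10 mg/kg

Among the compounds with values here, the only measured step, a 2.0-fold lower number from compound 1 to compound 2 (0.30 log units; within the scatter), lies within the scatter, so compound 2 and compound 1 are not separated by this assay. Compound 3 `CCc1nn(C)c2c1C(c1ccc(F)cc1)=NCC(=O)N2C` is the next compound to be measured. It differs from compound 2 by 4-fluorophenyl in place of 3-fluorophenyl on a carbon with a double bond to nitrogen. Within the data shown here, the one measured step concerns the methyl on the amide-type nitrogen, not the fluorophenyl group, so no measured step bears on this change. For compound 3 the expectation is therefore a step of no change at the digits printed from compound 2 to compound 3 (within the scatter), nothing beyond the scatter, and an estimated value of 10 mg/kg, with a range from 4 mg/kg to 30 mg/kg.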

Compound 3, minimum effective dose: > 40 mg/kg
Compound 3 ended at the assay's limit (the forecaster's own chance of this, stated with the estimate: 5%); middle value at least 4.0-fold (0.60 log units) away from the limit.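

In this assay, 4-fluorophenyl in place of 3-fluorophenyl on the carbon with a double bond to nitrogen gives an at least 4.0-fold higher number from compound 2 to compound 3 (0.60 log units; beyond the scatter). The two compounds have the same atoms, joined differently, so this position responds to where the fluorine sits on the phenyl group, a sensitivity that the earlier step on the amide-type nitrogen, within the scatter, did not reveal. Compound 3 stands at a limit of the assay, not at a number: the limit of > 40 mg/kg in this assay, at which 1 of the 3 values shown sits.

On these data alone, how far compound 3 lies past that limit stays open. Also open, as far as these compounds go, is how a plain phenyl or a methoxyphenyl group would behave at this position.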